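Three Methoxy Groups Placed on the Core of Compound 3

The compounds below may be only part of what the source reports. "The series", "measured", "known", "first", "only" and "open" are said of these compounds alone.

Compound 1 `COc1cc(C(=O)c2ccc3c(ccn3S(=O)(=O)c3ccc(/C=C/C(=O)NO)cc3)c2)cc(OC)c1OC` gives > 100000 nM in an assay on isolated protein for inhibition of polyamine deacetylase HDAC10 (Homo sapiens) (a higher number here means a weaker inhibitor, a lower number a stronger inhibitor), which is a limit of the assay rather than a number.
Compound 2 `COc1ccc(C(=O)c2ccc3c(ccn3S(=O)(=O)c3ccc(/C=C/C(=O)NO)cc3)c2)cc1` gives > 100000 nM in this assay, again a limit.
Compound 3 `COc1cccc(C(=O)c2ccc3c(ccn3S(=O)(=O)c3cccc(/C=C/C(=O)NO)c3)c2)c1` gives 7740 nM in this assay.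

For the measured compounds named here, compound 3 therefore stands as the only compound with a measured number; the other two values sit at the limit of > 100000 nM in this assay, at which 2 of the 3 values shown sit.

Compound 4 `COc1cc(C(=O)c2ccc3c(ccn3S(=O)(=O)c3cccc(/C=C/C(=O)NO)c3)c2)cc(OC)c1OC` has not yet been measured. It differs from compound 3 in one place: 3,4,5-trimethoxyphenyl in place of 3-methoxyphenyl on a carbonyl carbon. The same kind of exchange appears once among the measured compounds, from compound 1 to compound 2, where the step that the two limits leave unreadable from compound 1 to compound 2 is not readable, since both ends are limits. Going by the values given here, compound 1, which carries the 3,4,5-trimethoxyphenyl group, sits at the limit, while compound 3, with 3-methoxyphenyl, gives a number, but these two also differ elsewhere, so no single step can be drawn from them.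

The expectation for compound 4 is thus a loss of potency compared with compound 3, of uncertain size, estimated at a 2.6-fold higher number from compound 3 to compound 4 (0.41 log units; beyond the scatter). Compound 4 is expected to give about 20000 nM in this assay, within roughly 4000 nM to 100000 nM, with a real chance that only a limit is returned.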

Compound 4, half-maximal inhibitory concentration: > 100000 nM
Compound 4: a limit, no number; the forecaster's own chance of this, stated with the estimate: 35%; middle value at least 5.0-fold (0.69 log units) from the limit.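

For the compounds shown here, on the carbonyl carbon, this pair gives the first readable comparison of the 3,4,5-trimethoxyphenyl and 3-methoxyphenyl groups with the rest of the structure unchanged, and in this assay the larger group brings a large loss of potency: an at least 12-fold higher number from compound 3 to compound 4 (1.11 log units; beyond the scatter). Compound 4 gives > 100000 nM, which is a limit of the assay and not a number. The steps joining two limits, including the one between the two compounds that carry the 3,4,5-trimethoxyphenyl group, cannot be read, so compound 3 remains the only compound here with a measured number: the limit of > 100000 nM in this assay, at which 3 of the 4 values shown sit.

The compounds shown cannot tell whether a single further methoxy group on the 3-methoxyphenyl ring would already cost potency, or what an amine or a carboxylic acid on that ring would do in this assay. From the compounds shown here alone, it also remains open whether any group on the carbonyl carbon can bring a measurable number when the 4-(2-(hydroxycarbamoyl)ethenyl)phenyl group sits on the sulfonyl sulfur.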